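The source may hold more compounds than are shown below. What is called first, only, known or untested is meant among the compounds shown, and "the series" means these compounds.

In an ADME assay for permeability (on this read-out lower numbers stand for lower permeability and higher numbers for higher permeability), compound 1 `CNC(=O)c1cc(C(=O)N[C@H]2CC[C@H](O)CC2)c([C@@H](C)c2cccc(OC)c2)o1` gives 44 nm/s. Two related compounds can be set beside it: compound 2 `CNC(=O)c1cc(C(=O)N[C@H]2CC[C@H](OC)CC2)n([C@@H](CO)c2ccccc2)n1` gives 39 nm/s, and compound 3 `CC[C@@H](c1ccccc1)n1nc(C(=O)NC)cc1C(=O)N[C@H]1CC[C@H](O)CC1` gives 70 nm/s. All three numbers lie within the usual scatter of repeated measurements, so compound 1 cannot be told apart from either of the others. Compound 4 `CNC(=O)c1cc(C(=O)N[C@H]2CC[C@H](O)CC2)c([C@@H](C)c2ccccc2)o1` differs from compound 1 in one place: hydrogen in place of methoxy on an aromatic carbon. In words, hydrogen stands in place of methoxy on an aromatic carbon, turning 3-methoxyphenyl to phenyl. Among the measured compounds shown here, no measured pair shows this change, so no step beyond the scatter is expected in this assay, in either direction. The expected change is a 1.3-fold higher number from compound 1 to compound 4 (0.10 log units; within the scatter). For compound 4 the estimate is 55 nm/s, with an expected range of 28 nm/s to 110 nm/s.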

Compound 4, apparent permeability in the ADME assay: 42 nm/s
Beside the measured number, compound 4's estimate is 1.3-fold (0.12 log units) above it; measured number inside the range.
By their numbers in the ADME assay, from the lowest: compounds 2, 4, 1 and 3 (each within the scatter of the next).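

Among the compounds shown here, the earlier compounds held no pair differing in one place, so this is the first direct reading of this change: in the ADME assay compound 1 gives 44 nm/s and compound 4 gives 42 nm/s as measured. In the ADME assay, hydrogen in place of methoxy on the aromatic carbon gives a 1.0-fold lower number from compound 1 to compound 4 (0.02 log units; within the scatter) and leaves the two compounds indistinguishable. In a physicochemical assay for solubility, read by HPLC, in simulated intestinal fluid, with a stated time of 16 h, at pH 6.5 (a higher number here means a more soluble compound, a lower number a less soluble compound), compound 1 gives 868 ug/mL and compound 4 gives 827 ug/mL and the same change gives a 1.0-fold lower number from compound 1 to compound 4 (0.02 log units; within the scatter) with the same outcome, so at this position methoxy and hydrogen cannot be told apart on either read-out. On these data alone, whether an amine, a carboxylic acid or a longer chain at this place would read the same remains open. No measurement shown here accounts for these results.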